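Swapping the sulfonyl aryl substituent: nitro to chloro

The source may report more compounds than this note shows. Statements on the series, on what has been measured and on what is new or still open speak of the compounds shown alone.

Measured in a functional assay on RS4-11 cells (Homo sapiens) for inhibition, read by CCK-8 assay, with a stated time of 48 h, tested at 20 uM; a higher number here means more inhibition of growth at the concentration tested, a lower number less inhibition of growth:
- compound 1 `N#C/C(=C\c1ccccc1OS(=O)(=O)c1ccc(Cl)cc1)C(=O)Nc1nnc(Cc2cccc3ccccc23)s1`: 68%
- compound 2 `Cc1ccc(Cc2nnc(NC(=O)/C(C#N)=C/c3ccccc3OS(=O)(=O)c3ccc(C)cc3)s2)cc1`: 66%
- compound 3 `Cc1ccc(Cc2nnc(NC(=O)/C(C#N)=C/c3ccccc3OS(=O)(=O)c3ccc([N+](=O)[O-])cc3)s2)cc1`: 64%

The three values lie within the scatter of each other, so compound 3 does not separate from compound 1 or compound 2 in this assay.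

The unmeasured compound 4 `Cc1ccc(Cc2nnc(NC(=O)/C(C#N)=C/c3ccccc3OS(=O)(=O)c3ccc(Cl)cc3)s2)cc1` differs from compound 3 by chloro in place of nitro on an aromatic carbon. This is chloro in place of nitro on an aromatic carbon, para to a large group, turning (4-nitrophenyl)sulfonyl into (4-chlorophenyl)sulfonyl.

Among the compounds with values here, one measured step bears on this substituent: a number 2 percentage points lower from compound 2 to compound 3 (within the scatter), with nitro in place of methyl on an aromatic carbon. Within the data shown here, no exchange at this place has yet moved the read-out beyond the scatter, though that rests on a single pair, and no measured step has chloro entering or nitro leaving against chloro. No step beyond the scatter is therefore expected in this assay.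

The estimated step is a number 1 percentage points higher from compound 3 to compound 4 (within the scatter). For compound 4 the expected value is 65%, with an estimated range from 55% to 75%.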

Compound 4, percent growth inhibition at one concentration: 72%
Compound 4: middle estimate off by 7 percentage points, on the low side, within the range that was stated.
By their numbers in this assay, from the lowest: compounds 3, 2, 1 and 4 (each within the scatter of the next).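

In this assay, chloro in place of nitro on the aromatic carbon gives a number 8 percentage points higher from compound 3 to compound 4 (within the scatter), and chloro in place of methyl gives a number 6 percentage points higher from compound 2 to compound 4 (within the scatter), so with the rest of the structure held constant, compounds 2, 3 and 4 show that all three groups at this place fall within the scatter of one another. With the (4-chlorophenyl)sulfonyl group held constant, 4-methylphenyl in place of naphthalen-1-yl gives a number 4 percentage points higher from compound 1 to compound 4 (within the scatter), so this exchange at a second place in the series also leaves the read-out within the scatter. No measurement on hand accounts for these readings.

As far as these compounds go, whether an amine or a carboxylic acid at the place of the chloro would take the read-out beyond the scatter remains open. Readings at a single concentration also leave open whether compounds 1, 2, 3 and 4 would separate across a full concentration series.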